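A Methyl Added Where Both Neighbours Sit Beyond the Limit

The source may report more compounds than this note shows. Statements on the series, on what has been measured and on what is new or still open speak of the compounds shown alone.

Compound 1 `O=C(NCCCO)c1cnc2ccccc2c1Cl` and compound 2 `COC(=O)CNC(=O)c1cnc2ccccc2c1Cl` share one core and differ only on a saturated chain carbon bound to an amide-type nitrogen. In an ADME assay on CCRF-CEM cells (Homo sapiens) for cytotoxicity (on this read-out higher numbers stand for lower toxicity in this test and lower numbers for higher toxicity in this test), compound 1 gives > 100 uM, which is a limit of the assay rather than a number. In this assay compound 2 likewise gives > 100 uM, again a limit. The step that the two limits leave unreadable from compound 1 to compound 2 therefore has no readable size, because both of its ends rest on (the limit of > 100 uM in this assay, at which 2 of the 2 values shown sit). Within the data shown here, compound 2 thus stands at the limit, beside the only other value shown, and nothing places it above or below that value.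

Compound 3 `COC(=O)[C@H](C)NC(=O)c1cnc2ccccc2c1Cl` has not yet been measured; it differs from compound 2 by methyl in place of hydrogen on a saturated chain carbon bound to an amide-type nitrogen and a carbonyl carbon. Only the unreadable step from compound 1 to compound 2 bears on this change, and it offers no measured size in this assay. With both known values sitting at the limit of > 100 uM in this assay, at which 2 of the 2 values shown sit, compound 3 is expected to sit there as well, with a step that the limit leaves unreadable from compound 2 to compound 3 estimated as none beyond the scatter. The estimate for compound 3 is 150 uM, between 60 uM and 400 uM.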

Compound 3, half-maximal toxic concentration: 81.3 uM
Compound 3: middle estimate off by 1.8-fold (0.27 log units), on the high side; the range from low to high includes it.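

In this assay compound 3 gives 81.3 uM, the only actual number among the three compounds shown. Among these compounds, a step can now be given a floor for the first time. Methyl in place of hydrogen on the saturated chain carbon bound to an amide-type nitrogen and a carbonyl carbon comes with an at least 1.2-fold lower number from compound 2 to compound 3 (0.08 log units; that floor lies within the scatter), and 1-(methoxycarbonyl)ethyl in place of 3-hydroxypropyl on the amide-type nitrogen comes with an at least 1.2-fold lower number from compound 1 to compound 3 (0.08 log units; that floor lies within the scatter). Neither floor shows a change beyond the scatter, and the true size of each step cannot be read because the other end of each rests on a limit: the limit of > 100 uM in this assay, at which 2 of the 3 values shown sit.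

The compounds shown leave open how large these two steps really are, and so whether the methyl on this carbon goes with any real difference in the read-out at all. They also leave open what an ethyl group or a longer chain on this carbon would give in this assay, or a carboxylic acid in place of the methoxycarbonyl group, or the opposite configuration at this carbon.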